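This account rests on a few compounds, and the source may have more. Where it says the series, first, only, none or still open, it means among the compounds named here.

Compound 2 `CC(CCCC(=O)O)c1cccc(OCc2ccc3ccccc3n2)c1` holds the higher of the two numbers recorded so far in an assay on membranes from lung (Cavia porcellus) for binding affinity to cysteinyl leukotriene receptor (Homo sapiens); on this read-out lower numbers stand for stronger inhibition and higher numbers for weaker inhibition: compound 2 gives 90 nM, whereas compound 1 `c1ccc2nc(COc3ccc(CC4CCCC4Cc4nnn[nH]4)cc3)ccc2c1` gives 15 nM, a gap that lies beyond the usual scatter of repeated measurements. The next step leads to compound 3 `c1cc(OCCCc2nnn[nH]2)cc(OCc2ccc3ccccc3n2)c1`, which differs from compound 2 in a single place: 3-(1H-tetrazol-5-yl)propoxy in place of 4-carboxy-1-methylbutyl on an aromatic carbon. Among the compounds with values here, no pair of measured compounds that differ in one place is available, so the size of this step has to be judged from the two values alone. A drop in the number of the order of a 2.3-fold lower number from compound 2 to compound 3 (0.35 log units; beyond the scatter) is expected, because compound 1 gives 15 nM in this assay and sets the lower of the two known marks. On that basis compound 3 is expected to give about 40 nM in this assay, with a likely range from 10 nM to 160 nM.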

Compound 3, inhibition constant: 42 nM
Compound 3: the middle estimate sits 1.1-fold (0.02 log units) below what was measured; measured number inside the range.
By their numbers in this assay, from the lowest: compound 1; then compound 3; then compound 2.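

In this assay, the aromatic carbon that carries the acidic chain in compound 2 accepts a tetrazole-bearing chain in place of the carboxylic acid chain: the change to 3-(1H-tetrazol-5-yl)propoxy gives a 2.1-fold lower number from compound 2 to compound 3 (0.33 log units; beyond the scatter) and is a modest gain. Within the data shown here, the carboxy group of 4-carboxy-1-methylbutyl is therefore not needed at this position for the number to stay in this range, and this is the first step read at this place. No measurement on hand accounts for the size of this step.

The exchange alters the end group, the chain and its branching methyl all at once, so the compounds shown do not assign the gain to any one of them. A carboxylic acid on the same propoxy chain, or a longer chain ending in the tetrazole, would be needed to separate these parts.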